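The source may report more compounds than this note shows. Statements on the series, on what has been measured and on what is new or still open speak of the compounds shown alone.

Measured so far in a physicochemical assay for lipophilicity; a lower number here means a more polar compound, a higher number a more lipophilic compound:
- compound 1 `Clc1cccc(Cl)c1C1=NC(c2ccccc2)CO1`: 3.69
- compound 2 `Fc1ccccc1C1=NC(c2ccccc2)CO1`: 3.51

Compound 2, at 3.51, stands within the usual scatter of compound 1, so the two values cannot be told apart in this assay. The next compound, compound 3 `Fc1cccc(Cl)c1C1=NC(c2ccccc2)CO1`, has not yet been measured. It comes from compound 2 through one change: chloro in place of hydrogen on an aromatic carbon, ortho to a large group and meta to a fluoro group. Within the data shown here, no measured pair of compounds differs in a single place, so the data give no direct size for this change. Among the measured compounds shown here, the only guide is compound 1, which also carries chloro and gives 3.69. A small rise, close to the scatter, is expected for the step of a number 0.24 log units higher from compound 2 to compound 3 (within the scatter). For compound 3 the estimated value is 3.75, with an expected range of 3.45 to 4.05.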

Compound 3, partition coefficient: 3.45
For compound 3 the middle estimate is 0.30 log units above the measured one, within the range that was stated.
By their numbers in this assay, from the lowest: compounds 3, 2 and 1 (each within the scatter of the next).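

In this assay, chloro in place of hydrogen on an aromatic carbon, ortho to a large group and meta to a fluoro group, gives a number 0.06 log units lower from compound 2 to compound 3 (within the scatter) and so offers the first direct size for this change: at this position, the step cannot be told from none. Fluoro in place of chloro on an aromatic carbon gives a number 0.24 log units lower from compound 1 to compound 3 (within the scatter) and likewise cannot be resolved, so neither single change at this position separates its pair. Nothing available here offers an explanation for either step.

On these data alone, whether an amine, a carboxylic acid or a longer chain in place of the chloro group would shift the number in this assay beyond the scatter remains open. Also open, as far as these compounds go, is whether the chloro step would keep its size on a ring without the fluoro group.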